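Swapping a Silyl Ether for Bromine on the Anilide Ring

A few compounds are considered here, and "the series" means these few. Any claim that something is new, unique, unknown or untested is made for them only; others in the source may bear on it.

Measured compounds:
- Compound 1 `Nc1cc(O)ccc1NC(=O)c1ccc(CNc2nccc(-c3cccnc3)n2)cc1`: in an assay on isolated protein for inhibition of protein deacetylase HDAC6 (Homo sapiens), read by fluorescence, with stated times of 3 h and 60 min (on this read-out higher numbers stand for weaker inhibition and lower numbers for stronger inhibition), compound 1 gives > 20000 nM, which is a limit of the assay and not a number.
- Compound 2 `CC(C)(C)[Si](C)(C)OCc1ccc(NC(=O)c2ccc(CNc3nccc(-c4cccnc4)n3)cc2)c(N)c1`: in this assay compound 2 gives > 20000 nM, likewise a limit of the assay.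

Compound 2 stands at the limit of the assay, and so does compound 1; the step that the two limits leave unreadable from compound 1 to compound 2 therefore cannot be read, and neither compound can be ranked against the other. The evidence the limit of > 20000 nM in this assay, at which 2 of the 2 values shown sit, is all the account has to go on.

Compound 3 `Nc1cc(Br)ccc1NC(=O)c1ccc(CNc2nccc(-c3cccnc3)n2)cc1` is the next member of the series. It differs from compound 2 in one place: one bromine atom in place of a group of 9 heavy atoms (7 carbon, 1 oxygen, 1 silicon; no ring), on an aromatic carbon. Going by the values given here, no measured step bears directly on this change, since the only step known connects two limits. The account can therefore expect nothing more than that compound 3 most likely also ends at a limit in this assay, with no readable step a number no higher from compound 2 to compound 3 (the limit leaves the size open) beyond the scatter. For compound 3 the estimate is 20000 nM, spanning from 7000 nM to 60000 nM.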

Compound 3, half-maximal inhibitory concentration: > 20000 nM
Compound 3: a limit, no number; the forecaster's own chance of this, stated with the estimate: 70%; the middle value sits exactly at the limit.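

Compound 3 ends at a limit of the assay, as compound 1 and compound 2 do, so no step among these three compounds can be read in this assay: the limit of > 20000 nM in this assay, at which 3 of the 3 values shown sit. The compounds shown leave open whether bromo, hydroxy and the larger silicon-bearing group differ at all in their inhibition of the enzyme.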